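Fluoro to chloro on the aniline-type ring

The source may report more compounds than this note shows. Statements on the series, on what has been measured and on what is new or still open speak of the compounds shown alone.

Measured in a functional assay on NCI-N87 cells (Homo sapiens) for antiproliferative activity; a higher number here means a weaker inhibitor, a lower number a stronger inhibitor:
- compound 1 `C#Cc1cccc(Nc2ncnn3ccc(CN4CCC(N)CC4)c23)c1`: 120 nM
- compound 2 `CC(C)Nc1ncnn2ccc(CN3CCC(N)CC3)c12`: "not determined" (no result reported)
- compound 3 `NC1CCN(Cc2ccn3ncnc(Nc4cccc(F)c4)c23)CC1`: 280 nM

Going by the values given here, only two compounds carry a number, and compound 3, at 280 nM, holds the higher of the two, so it is the weaker inhibitor of that pair. Compound 2 gives no basis for comparison.

The next compound is compound 4 `NC1CCN(Cc2ccn3ncnc(Nc4cccc(Cl)c4)c23)CC1`, which keeps everything in compound 3 except one substituent: chloro in place of fluoro on an aromatic carbon. The change takes 3-fluorophenyl to 3-chlorophenyl.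

Among the compounds with values here, one measured step bears on this change: a 2.3-fold higher number from compound 1 to compound 3 (0.37 log units; beyond the scatter), a modest step with fluoro in place of ethynyl. Within the data shown here, it is not the same exchange, and no chloro compound has been measured yet, so it serves only as a guide to size. A change at this position has so far moved the number only modestly, and a swap of one halogen for another is expected to move it no further. The expected change is a 1.6-fold lower number from compound 3 to compound 4 (0.19 log units; within the scatter), a small move towards a lower number that stays within the scatter. For compound 4 the estimated value is 180 nM, with an expected range of 70 nM to 450 nM.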

Compound 4, half-maximal inhibitory concentration: 60 nM
The estimate for compound 4 lay 3.0-fold (0.48 log units) above the measured number; measured number below the stated range.
By their numbers in this assay, from the lowest: compounds 4 and 1 (each within the scatter of the next); then compound 3.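

In this assay, one halogen cannot simply stand in for another at this position: a 4.7-fold lower number from compound 3 to compound 4 (0.67 log units; beyond the scatter), although the exchange only swaps one heavy atom for another, with no ring, hydrogen-bond donor, hydrogen-bond acceptor or net charge entering or leaving. Chloro and ethynyl cannot be separated here, at a 2.0-fold lower number from compound 1 to compound 4 (0.30 log units; within the scatter), whereas a 2.3-fold higher number from compound 1 to compound 3 (0.37 log units; beyond the scatter) shows that compound 3 also stands apart from compound 1, leaving the 3-fluorophenyl compound as the weakest of the three measured inhibitors. No measurement at hand accounts for this difference between fluoro and chloro.

Still open, going by these compounds, is how bromo, methyl or methoxy at the same place would compare with chloro and ethynyl, and whether an unsubstituted phenyl would sit closer to the fluoro or to the chloro compound. Also open, on these data alone, is whether the step between the two halogens would persist if another amine, or a carboxylic acid, replaced the amine-bearing side chain on the shared core, since all three numbers come from compounds carrying that one side chain and from this assay alone.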